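This account rests on a few compounds, and the source may have more. Where it says the series, first, only, none or still open, it means among the compounds named here.

Working notes on a small set of compounds built on one shared core, all tested in a functional assay, read by fluorescence and spectrophotometry, with a stated time of 1 h; a lower number here means that less compound is needed, a higher number that more compound is needed for the effect.

Compound 1 is `O=S(=O)(/C=C/c1ccc(O)c(O)c1)CC1CCCO1` and in this assay compound 1 gives 10500 nM. Compound 2 is `C=CCCCCCS(=O)(=O)/C=C/c1ccc(O)c(O)c1`; compound 2 gives 7100 nM. Compound 3 is `O=S(=O)(/C=C/c1ccc(O)c(O)c1)CC1CCCCC1`; compound 3 gives 7500 nM. The three measured steps all change the group on a saturated chain carbon bound to a sulfonyl sulfur and all stay within the scatter: a 1.5-fold lower number from compound 1 to compound 2 (0.17 log units; within the scatter), a 1.4-fold lower number from compound 1 to compound 3 (0.15 log units; within the scatter) and a 1.1-fold higher number from compound 2 to compound 3 (0.02 log units; within the scatter). Compound 3 therefore stands in the middle of a tight cluster, nearest to compound 2 and furthest from compound 1, with neither gap large enough to count as a difference.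

Compound 4 is `O=S(=O)(/C=C/c1ccc(O)c(O)c1)CCC1CCCC1`. Against compound 3 the change is cyclopentylmethyl in place of cyclohexyl on a saturated chain carbon bound to a sulfonyl sulfur. Among the compounds with values here, the steps that bear on it are those from compound 1 to compound 3 and from compound 2 to compound 3, since both swap the group at the same place, and both were within the scatter. On that basis no step beyond the scatter is expected in this assay.

Compound 4 is thus expected to give about 7500 nM, estimated between 3500 nM and 16000 nM. This estimate means an expected step of no change at the digits printed from compound 3 to compound 4 (within the scatter), within the scatter.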

Compound 4, half-maximal effective concentration: 6800 nM
Compound 4: middle estimate off by 1.1-fold (0.04 log units), on the high side, and the stated range covers the measured number.
By their numbers in this assay, from the lowest: compounds 4, 2, 3 and 1 (each within the scatter of the next).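

In this assay the swap of a six-membered for a five-membered non-aromatic ring of carbon only, with the same atoms joined differently, gives a 1.1-fold lower number from compound 3 to compound 4 (0.04 log units; within the scatter) and so adds a change of ring size to the changes at this place that stay within the scatter. The two other readings are a 1.0-fold lower number from compound 2 to compound 4 (0.02 log units; within the scatter) and a 1.5-fold lower number from compound 1 to compound 4 (0.19 log units; within the scatter) and they place cyclopentylmethyl in the same tight cluster as the open hex-5-en-1-yl chain, the oxolan-2-yl group and cyclohexyl, so that all four compounds lie within the scatter of one another and the series shows no preference among these groups. No measured information is available that accounts for this flat reading.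

Whether this tolerance extends to a primary amine, a carboxylic acid, a phenyl ring or a much longer alkyl chain on the same saturated chain carbon remains open, since the four groups shown do not separate and so do not mark where a real step would begin. Also open, as far as these compounds go, is whether a change elsewhere in the shared core would move the number beyond the scatter, and whether the groups at this place would then still read alike.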